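The source may hold more compounds than are shown below. What is called first, only, known or untested is meant among the compounds shown, and "the series" means these compounds.

Compound 1 `Brc1ccc(Oc2ccc(/C=N/Nc3nc4ccccc4s3)cc2)cc1` gives 5.5 in a physicochemical assay for lipophilicity, in phosphate buffer, measured as octanol-water partition, with a stated time of 24 h; on this read-out higher numbers stand for higher lipophilicity and lower numbers for lower lipophilicity.
Compound 2 `O=[N+]([O-])c1ccc(Oc2ccc(/C=N/Nc3nc4ccccc4s3)cc2)cc1` gives 5.1 in this assay.

Among the measured compounds shown here, compound 2 stands lowest of the two numbers; the only step measured, a number 0.40 log units lower from compound 1 to compound 2 (beyond the scatter), is modest but beyond the scatter. Compound 3 `Cc1cc(Oc2ccc(/C=N/Nc3nc4ccccc4s3)cc2)ccc1Cl` carries the change (4-chloro-3-methylphenyl in place of 4-nitrophenyl on an oxygen on an aromatic ring). The step from compound 1 to compound 2 bears on this change, since it also swaps a halogen against the nitro group, and compound 3 adds a methyl as well. An upward step of roughly that size or somewhat larger is therefore expected, a number 0.80 log units higher from compound 2 to compound 3 (beyond the scatter), and compound 3 is estimated at 5.9, between 5.5 and 6.3.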

Compound 3, partition coefficient: 5.5
Estimate against measurement, compound 3: 0.40 log units above, within the range that was stated.
By their numbers in this assay, from the lowest: compound 2; then compounds 1 and 3 (each within the scatter of the next).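

At this position, on an oxygen on an aromatic ring, 4-chloro-3-methylphenyl in place of 4-nitrophenyl gives a number 0.40 log units higher from compound 2 to compound 3 (beyond the scatter) in this assay, whereas in place of 4-bromophenyl it gives no change at the digits printed from compound 1 to compound 3 (within the scatter). The two halogen-bearing groups thus cannot be told apart here, and only the 4-nitrophenyl of compound 2 stands apart from both. No measurement offers an explanation for this. As far as these compounds go, it remains open how the chlorine and the methyl count separately, and where an amine or a carboxylic acid on this ring would fall.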